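Notes on the acyl group of the shared core

The compounds below may be only part of what the source reports. "The series", "measured", "known", "first", "only" and "open" are said of these compounds alone.

Compound 3 `CCCCCCCCC(=O)N1c2ccccc2CCC1C(=O)Nc1cc(C(F)(F)F)cc(C(F)(F)F)c1` gives 7430 nM in a functional assay on PC-3 cells (Homo sapiens) for cytotoxicity, read by sulforhodamine B assay, with a stated time of 72 h (on this read-out higher numbers stand for weaker inhibition of growth and lower numbers for stronger inhibition of growth), the lowest of the two numbers shown; compound 1 `O=C(Nc1ccccc1O)C1CCc2ccccc2N1C(=O)c1ccccc1Cl` gives 60000 nM. Compound 2 `CC(=O)N1c2ccccc2CCC1C(=O)Nc1cc(C(F)(F)F)cc(C(F)(F)F)c1` returns only a limit, > 70000 nM (the limit of > 70000 nM in this assay, at which 1 of the 3 values shown sits). Among the compounds with values here, the single measured step, an at least 9.4-fold lower number from compound 2 to compound 3 (0.97 log units; beyond the scatter), shows a long chain on the carbonyl carbon lowering the number markedly. Compound 4 `O=C(Nc1cc(C(F)(F)F)cc(C(F)(F)F)c1)C1CCc2ccccc2N1C(=O)c1cccc(Cl)c1` differs from compound 3 by 3-chlorophenyl in place of octyl on a carbonyl carbon. Within the data shown here, no measured step covers this exchange; compound 1 carries an aroyl group of another kind together with a different amide and sits well above compound 3, so an aromatic acyl group is not expected to match the chain. Compound 4 is therefore expected to give a higher number than compound 3, an estimated step of a 3.0-fold higher number from compound 3 to compound 4 (0.47 log units; beyond the scatter), landing near 22000 nM (range 6000 nM to 70000 nM).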

Compound 4, concentration for 50% growth inhibition: 1050 nM
Estimate against measurement, compound 4: 21-fold (1.32 log units) above; the measured number lies below the stated range.
By their numbers in this assay, from the lowest: compound 4; then compound 3; then compound 1. At a limit, above all of these: compound 2.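

On a carbonyl carbon whose other neighbours are amide-type nitrogen in a ring, an aromatic acyl group does better than the long chain: a 7.1-fold lower number from compound 3 to compound 4 (0.85 log units; beyond the scatter). A long chain is thus not required for a low number here, and 3-chlorophenyl in place of methyl gives an at least 66-fold lower number from compound 2 to compound 4 (1.82 log units; beyond the scatter). That step starts from a limit, not a number: the limit of > 70000 nM in this assay, at which 1 of the 4 values shown sits.

Open, as far as these compounds go, is what the chlorine contributes compared with plain phenyl on the same carbonyl carbon. Also open, from the compounds shown here alone, is whether an amine on the acyl group, or a chain longer than octyl, would keep the number low.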